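Allylamino versus butylamino on the shared dienone core

The source may report more compounds than this note shows. Statements on the series, on what has been measured and on what is new or still open speak of the compounds shown alone.

Measured so far:
compound 1 `COc1cc(/C=C/C(=O)/C=C(/C=C/c2ccc(OC(C)=O)c(OC)c2)NC2CCCCC2)ccc1OC(C)=O`, 113%
compound 2 `C=CCNC(=C\C(=O)/C=C/c1ccc(O)c(OC)c1)/C=C/c1ccc(O)c(OC)c1`, 267%
compound 3 `CC(C)CNC(=C\C(=O)/C=C/c1ccc(O)cc1)/C=C/c1ccc(O)cc1`, 119%

In a functional assay on EA.hy 926 cells (Homo sapiens), read by fluorescence, tested at 10 uM (on this read-out higher numbers stand for a stronger effect at the one concentration tested and lower numbers for a weaker effect), compound 1 gives 113%, compound 3 gives 119%, and compound 2 gives 267%. Compound 2 stands highest of the three numbers; its gap to compound 3 and its gap to compound 1 both lie beyond the scatter, so it is the strongest of the measured set on this read-out. Compound 1 and compound 3 lie within the scatter of each other and are not ordered. Compound 3 differs from compound 2 in more than one place, so nothing is drawn from that pair about the amine chain alone.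

Compound 4 `CCCCNC(=C\C(=O)/C=C/c1ccc(O)c(OC)c1)/C=C/c1ccc(O)c(OC)c1` has not been measured. It differs from compound 2 as follows: propyl in place of vinyl on a saturated chain carbon bound to an amine nitrogen. Within the data shown here, no single-point step on the amine chain has been measured in this set, so the size of the step is open. A small loss, or none beyond the scatter, is expected in this assay, since the core and both aryl groups of compound 2 are kept unchanged. For compound 4 the expected value is 200%, within 110% to 290%, which means an estimated step of a number 67 percentage points lower from compound 2 to compound 4 (beyond the scatter).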

Compound 4, a percentage reported as activity, at one concentration (the size of the read-out at that concentration, not a potency): 439%
Estimate against measurement, compound 4: 239 percentage points below, and the stated range ends below it.
By their numbers in this assay, from the lowest: compounds 1 and 3 (each within the scatter of the next); then compound 2; then compound 4.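

With the shared core and both aryl groups held constant, the amine chain proves to be a position that can move the read-out strongly in this assay: going from allylamino to butylamino gives a number 172 percentage points higher from compound 2 to compound 4 (beyond the scatter) on this single-point measure. Among these compounds, this is the first single-place comparison, and it shows that the chain is not a silent part of the structure and that, of these two chains, butylamino gives the higher number. Nothing measured here accounts for the size of this step, so its origin remains unexplained.

This one pair cannot separate the loss of the double bond from the added chain length, so a propylamino chain, which would keep the saturation of butylamino with the shorter length of allylamino, and a hexylamino chain, which would extend the chain further, are the informative comparisons. As far as these compounds go, whether the same step holds with other aryl groups also remains open, as would be tested by a butylamino analogue of compound 3 carrying the same hydroxyphenyl groups.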